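Compound 3 to compound 4: losing the high half-life group

The source may report more compounds than this note shows. Statements on the series, on what has been measured and on what is new or still open speak of the compounds shown alone.

In an ADME assay on microsomes from liver (Rattus norvegicus) for metabolic stability (a higher number here means that the compound lasts longer, a lower number that the compound disappears faster), compound 3 (`CC(C)C(Cc1noc(=O)[nH]1)c1ccc(-c2ccc3cccc(F)c3c2)[nH]c1=O`) gives > 3 h, which is a limit and not a number. The series therefore holds (the limit of > 3 h in this assay, at which 1 of the 3 values shown sits). Compound 1 (`CC(C)C(c1ccc(-c2ccc3cccc(F)c3c2)[nH]c1=O)N1CCCCS1(=O)=O`) gives 0.07 h, and compound 2 (`CC(C)C(c1cnc(N)s1)c1ccc(-c2ccc3cccc(F)c3c2)[nH]c1=O`) gives 0.0983 h. These two are separated by a 1.4-fold higher number from compound 1 to compound 2 (0.15 log units; within the scatter), although a six-membered non-aromatic ring stands in one and a five-membered aromatic ring in the other.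

Compound 4 (`CC(C)C(/C=C1/CCNC1=O)c1ccc(-c2ccc3cccc(F)c3c2)[nH]c1=O`) differs from compound 3 as follows: a group of 7 heavy atoms (5 carbon, 1 nitrogen, 1 oxygen; one five-membered non-aromatic ring with 1 hetero atom) in place of a group of 7 heavy atoms (3 carbon, 2 nitrogen, 2 oxygen; one five-membered aromatic ring with 3 hetero atoms), on a saturated chain carbon bound to an aromatic carbon and a saturated chain carbon. The five-membered aromatic ring with 3 hetero atoms that leaves is carried by compound 3 alone. The two measured steps that introduce it are both large: an at least 42-fold higher number from compound 1 to compound 3 (1.63 log units; beyond the scatter) and an at least 30-fold higher number from compound 2 to compound 3 (1.48 log units; beyond the scatter). Compound 4 gives up this group, so its value is expected to fall back towards the short values, with compound 2 at 0.0983 h as the nearest guide. Among the compounds with values here, no measured compound carries the five-membered non-aromatic ring with 1 hetero atom that enters, so the range is kept wide. An estimated at least 15-fold lower number from compound 3 to compound 4 (1.17 log units; beyond the scatter) is expected in this assay, a drop beyond the scatter. For compound 4 the expected half-life is 0.2 h, with an estimated range of 0.07 h to 1 h.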

Compound 4, half-life: 0.06 h
Beside the measured number, compound 4's estimate is 3.3-fold (0.52 log units) above it; the measured number lies below the stated range.
By their numbers in this assay, from the lowest: compounds 4, 1 and 2 (each within the scatter of the next). At a limit, above all of these: compound 3.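

In this assay, an at least 50-fold lower number from compound 3 to compound 4 (1.69 log units; beyond the scatter) shows that a five-membered non-aromatic ring with 1 hetero atom at this place does not keep the long half-life, even though the group that enters and the group that leaves both count 7 heavy atoms and 1 hydrogen-bond donor, so these counts alone do not set the read-out. Within the data shown here, with a 1.6-fold lower number from compound 2 to compound 4 (0.21 log units; within the scatter) and a 1.2-fold lower number from compound 1 to compound 4 (0.07 log units; within the scatter), both within the scatter, three differently built groups on this saturated chain carbon now give values that cannot be told apart, and the five-membered aromatic ring with 3 hetero atoms remains the only group here that separates from them. The value of compound 3 is a limit and not a number, so the full size of the drop stays unknown: the limit of > 3 h in this assay, at which 1 of the 4 values shown sits.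

The compounds shown leave open which part of the five-membered aromatic ring with 3 hetero atoms goes with the long half-life, since compound 3 alone carries it. They also leave open whether a carboxylic acid or a tetrazole at this place would read like compound 3 or like compounds 1, 2 and 4.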